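Adding a Bromine to a Trimethoxy Chalcone

The compounds below may be only part of what the source reports. "The series", "measured", "known", "first", "only" and "open" are said of these compounds alone.

Compound 1 `COc1cc(O)c(C(=O)/C=C/c2ccc(F)cc2)c(OC)c1` and compound 2 `COc1cc(OC)c(C(=O)/C=C/c2ccccc2)c(OC)c1` were both tested in a functional assay on Caco-2 cells (Homo sapiens), read by fluorescence and BrdU incorporation, with a stated time of 48 h, tested at 10 uM; on this read-out higher numbers stand for a weaker effect at the one concentration tested and lower numbers for a stronger effect. In this assay compound 1 gives 49%, and compound 2 gives 38%. Compound 2 thus stands lowest of the two numbers, with compound 1 beyond the usual scatter above it. Compound 3 `COc1cc(OC)c(C(=O)/C=C/c2ccc(Br)cc2)c(OC)c1` is the next step: bromo in place of hydrogen on an aromatic carbon. Within the data shown here, compounds 1 and 2 differ in more than one place, so no measured step isolates this change; only a small step in this assay is expected, in either direction. The step from compound 2 to compound 3 is estimated at a number 5 percentage points lower from compound 2 to compound 3 (within the scatter). Compound 3 is expected to give about 33%, most likely between 18% and 50%.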

Compound 3, a percentage reported as activity, at one concentration (the size of the read-out at that concentration, not a potency): 36%
The estimate for compound 3 lay 3 percentage points below the measured number, and the stated range covers the measured number.
By their numbers in this assay, from the lowest: compounds 3 and 2 (each within the scatter of the next); then compound 1.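

In this assay, going from phenyl to 4-bromophenyl gives a number 2 percentage points lower from compound 2 to compound 3 (within the scatter). Among these compounds, this is the first change here that can be read on its own, and it shows that a bromine atom can sit on this aromatic carbon, para to a large group, without a shift beyond the scatter. Nothing available explains this result.

On these data alone, whether an amine or a carboxylic acid on the same carbon would also stay within the scatter remains open. So does whether bromo in place of hydrogen would give a similar result on the core of compound 1.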